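This account rests on a few compounds, and the source may have more. Where it says the series, first, only, none or still open, it means among the compounds named here.

Compound 3 `ClCc1ccccc1Cn1cnc2c(Cl)nc(Cl)nc21` gives the lowest of the three numbers in a functional assay on SK-MEL-2 cells (Homo sapiens) for cytotoxicity, read by sulforhodamine B assay, with a stated time of 48 h (a lower number here means a stronger inhibitor of growth, a higher number a weaker inhibitor of growth), at 4360 nM. Compound 2 `ClCc1ccccc1Cn1cnc2ncnc(Cl)c21` gives 19500 nM in this assay, and compound 1 `Nc1nc(Cl)c2ncn(Cc3ccccc3CCl)c2n1` gives 81300 nM. Compound 4 `ClCc1ccccc1Cn1cnc2c(Cl)ncnc21` differs from compound 3 by hydrogen in place of chloro on an aromatic carbon. For the measured compounds named here, the only measured step at that carbon is a 19-fold lower number from compound 1 to compound 3 (1.27 log units; beyond the scatter), which swaps one substituent for another rather than removing it, so it bears on the new step only loosely; no step in the set removes a group outright. The direction of that step suggests the chloro matters at this position, so compound 4 is expected to give a higher number, with a step of a 2.8-fold higher number from compound 3 to compound 4 (0.44 log units; beyond the scatter) expected. Compound 4 is estimated at 12000 nM, with a range from 3500 nM to 40000 nM.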

Compound 4, concentration for total growth inhibition: 18200 nM
Compound 4: the middle estimate sits 1.5-fold (0.18 log units) below what was measured; the measured number falls inside the stated range.
By their numbers in this assay, from the lowest: compound 3; then compounds 4 and 2 (each within the scatter of the next); then compound 1.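

With hydrogen at this carbon between two ring nitrogen atoms, this assay now has a reference point for judging each substituent on its own. Chloro in compound 3 gives the lower number when replaced by hydrogen gives (a 4.2-fold higher number from compound 3 to compound 4 (0.62 log units; beyond the scatter)), whereas amino gives the higher number when hydrogen replaces it (a 4.5-fold lower number from compound 1 to compound 4 (0.65 log units; beyond the scatter)), so the two groups depart from hydrogen in opposite directions. No evidence is available to explain this order.

The compounds shown leave open how a bromo, methoxy or methyl group at this carbon would compare with chloro. They also leave open whether the same order holds on another core or in other cells.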